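A Nitrophenyl Chalcone Lactam Awaits Its Antiproliferative Reading

This account rests on a few compounds, and the source may have more. Where it says the series, first, only, none or still open, it means among the compounds named here.

Compound 1 `COc1ccccc1/C=C/C(=O)c1ccc(OCC(=O)N[C@H]2CCOC2=O)cc1` was tested in a functional assay on MCF7 cells (Homo sapiens) for antiproliferative activity, read by MTT assay, with a stated time of 72 h; on this read-out lower numbers stand for stronger inhibition and higher numbers for weaker inhibition. In that assay compound 1 reaches only the limit of the measurement, > 64000 nM, so no number is known for it. Two further compounds on the shared core behave alike. Compound 2 `Cc1cc(Cl)ccc1NCC(=O)N[C@H]1CCOC1=O` gives in this assay a limit of > 64000 nM. Compound 3 `O=C(CNc1ccccc1F)N[C@H]1CCOC1=O` gives in this assay a limit of > 64000 nM. Compound 1 therefore stands at the limit of > 64000 nM in this assay, at which 3 of the 3 values shown sit. Compound 4 `O=C(COc1ccc(C(=O)/C=C/c2cccc([N+](=O)[O-])c2)cc1)N[C@H]1CCOC1=O` differs from compound 1 by 3-nitrophenyl in place of 2-methoxyphenyl on a double-bonded chain carbon bound to a double-bonded chain carbon. Going by the values given here, no step between measured compounds is available, so the chemist cannot read the size of this change from a comparison; he expects nothing beyond the scatter, in no fixed direction, and estimates the step as a step that the limit leaves unreadable from compound 1 to compound 4. For compound 4 he estimates 70000 nM, between 20000 nM and 200000 nM, most likely a limit once more.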

Compound 4, half-maximal inhibitory concentration: > 64000 nM
Compound 4 gave a limit, no number (the forecaster's own chance of this, stated with the estimate: 75%); the middle value is on the limit's open side.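

Going by these compounds alone, compound 1 and compound 4 both give only a limit, so no step between them can be read: the limit of > 64000 nM in this assay, at which 4 of the 4 values shown sit. The compounds shown leave open what change on the shared core, if any, would give a measurable value in this assay.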